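The source may report more compounds than this note shows. Statements on the series, on what has been measured and on what is new or still open speak of the compounds shown alone.

Measured so far in a functional assay on A549 cells (Homo sapiens) for cytotoxicity, read by MTT assay, with a stated time of 24 h; on this read-out lower numbers stand for stronger inhibition and higher numbers for weaker inhibition:
- compound 1 `O=C(NN=C1CC(c2ccccc2)NC(c2ccccc2)C1)c1ccc(Cl)cc1` gives > 400000 nM, a limit of the assay.
- compound 2 `COc1ccc(C(=O)NN=C2CC(c3ccccc3)NC(c3ccccc3)C2)cc1` gives > 400000 nM, a limit of the assay.

For the measured compounds named here, compound 2 thus stands at the limit, and so does the only other value shown; the limit of > 400000 nM in this assay, at which 2 of the 2 values shown sit, covers both. The step from compound 1 to compound 2, a step that the two limits leave unreadable from compound 1 to compound 2, cannot be read. Compound 3 `Cc1ccc(C(=O)NN=C2CC(c3ccccc3)NC(c3ccccc3)C2)cc1` differs from compound 2 by methyl in place of methoxy on an aromatic carbon. Going by the values given here, no measured step bears on this change with a readable size. In this assay the step from compound 2 to compound 3 is expected to be a number no higher from compound 2 to compound 3 (the limit leaves the size open), nothing beyond the scatter. Compound 3 is expected to give 400000 nM, between 200000 nM and 2000000 nM, most likely again only a limit.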

Compound 3, half-maximal inhibitory concentration: > 400000 nM
Compound 3 was reported as a limit; the forecaster's own chance of this, stated with the estimate: 85%; the middle value lies on the limit itself.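

No new step can be read among compound 1, compound 2 and compound 3 in this assay, as all three stop at one limit: the limit of > 400000 nM in this assay, at which 3 of the 3 values shown sit.

From the compounds shown here alone, whether chloro, methoxy and methyl on the aromatic carbon differ at all in this read-out remains open.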